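Trifluoromethyl at the Aromatic Position: Compound 4 Expected

The compounds below may be only part of what the source reports. "The series", "measured", "known", "first", "only" and "open" are said of these compounds alone.

Measured in a functional assay on SW1573 cells (Homo sapiens) for inhibition, read by sulforhodamine B assay, with a stated time of 48 h; on this read-out lower numbers stand for stronger inhibition of growth and higher numbers for weaker inhibition of growth:
compound 1, `COC(=O)[C@@]1(C)CCC=C2[C@@H]1CC[C@@H](C)[C@]2(C)Cc1c[nH]c2ccccc12`, gives 7300 nM
compound 2, `COC(=O)[C@@]1(C)CCC=C2[C@@H]1CC[C@@H](C)[C@]2(C)Cc1c[nH]c2ccc(C)cc12`, gives 15000 nM
compound 3, `COC(=O)[C@@]1(C)CCC=C2[C@@H]1CC[C@@H](C)[C@]2(C)Cc1c[nH]c2ccc(F)cc12`, gives 7300 nM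

Compound 3 stands level with compound 1 at the digits shown, and the two together hold the lowest numbers of the three. Its nearest neighbour is compound 1, with no change at the digits printed from compound 1 to compound 3 (within the scatter); its furthest is compound 2, with a 2.1-fold lower number from compound 2 to compound 3 (0.31 log units; beyond the scatter).

The unmeasured compound 4, `COC(=O)[C@@]1(C)CCC=C2[C@@H]1CC[C@@H](C)[C@]2(C)Cc1c[nH]c2ccc(C(F)(F)F)cc12`, differs from compound 3 by trifluoromethyl in place of fluoro on an aromatic carbon. For the measured compounds named here, two measured steps bear on this position. One is a 2.1-fold higher number from compound 1 to compound 2 (0.31 log units; beyond the scatter), a methyl entering for hydrogen. The other is no change at the digits printed from compound 1 to compound 3 (within the scatter), a fluoro entering for hydrogen. Neither step is large, and of the two groups only the methyl moved the number beyond the scatter, upward. The trifluoromethyl of compound 4 brings in four heavy atoms where fluoro brought one, and on that basis a modest upward step is expected rather than none.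

Compound 4 is therefore expected to show a 1.5-fold higher number from compound 3 to compound 4 (0.18 log units; within the scatter) in this assay. The estimate for compound 4 is 11000 nM, with an expected range from 5000 nM to 25000 nM.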

Compound 4, concentration for 50% growth inhibition: 14000 nM
For compound 4 the middle estimate is 1.3-fold (0.10 log units) below the measured one, within the range that was stated.
By their numbers in this assay, from the lowest: compounds 1, 3, 4 and 2 (each within the scatter of the next, the first and the last beyond it).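

In this assay, trifluoromethyl at this aromatic carbon gives a 1.9-fold higher number from compound 1 to compound 4 (0.28 log units; within the scatter) and a 1.9-fold higher number from compound 3 to compound 4 (0.28 log units; within the scatter), so a group of four heavy atoms still leaves the number within the scatter of both the hydrogen and the fluoro compounds. It also gives a 1.1-fold lower number from compound 2 to compound 4 (0.03 log units; within the scatter), which places compound 4 within the scatter of the methyl compound as well, although compound 1 and compound 2 are themselves separated by a step beyond the scatter. For the compounds shown here, compound 4 therefore bridges the two ends of this short series without being separated from either, and trifluoromethyl, like methyl and fluoro, brings no step to a lower number beyond the scatter from compound 1.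

Nothing shown here explains any of these steps. On these data alone, whether an amine, a hydroxyl group or a carboxylic acid on this aromatic carbon would move the number beyond the scatter in either direction remains open, as does the effect of any of the present groups on the other carbons of the same ring.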